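The source may hold more compounds than are shown below. What is called first, only, known or untested is meant among the compounds shown, and "the series" means these compounds.

Working notes on the series. All compounds share one core carrying a varied aryl group on a nitrogen on an aromatic ring. Compound 1 `COc1cccnc1Nc1cc2[nH]c(-c3cccc(C(F)(F)F)c3)nc2cn1` gives 116000 nM in a physicochemical assay for solubility, using the shake flask method, measured as kinetic solubility, with a stated time of 20 h, at pH 2; a lower number here means a less soluble compound, a higher number a more soluble compound. Compound 2 `FC(F)(F)c1cccc(-c2nc3cnc(Nc4ccncn4)cc3[nH]2)c1` gives 200000 nM in this assay, and a 1.7-fold higher number from compound 1 to compound 2 (0.24 log units; within the scatter). Compound 3 `O=C(O)c1ccc(Nc2cc3[nH]c(-c4cccc(C(F)(F)F)c4)nc3cn2)nc1` is reported only as a limit in this assay, < 5000 nM. This is the limit of < 5000 nM in this assay, at which 1 of the 3 values shown sits. The falls an at least 23-fold lower number from compound 1 to compound 3 (1.36 log units; beyond the scatter) and an at least 40-fold lower number from compound 2 to compound 3 (1.60 log units; beyond the scatter) place compound 3 at the bottom of the numbers shown. Compound 4 `O=C(O)c1ccnc(Nc2cc3[nH]c(-c4cccc(C(F)(F)F)c4)nc3cn2)c1` differs from compound 3 by 4-carboxypyridin-2-yl in place of 5-carboxypyridin-2-yl on a nitrogen on an aromatic ring. Among the measured compounds shown here, no measured step exchanges the two carboxypyridinyl groups, and both measured steps into compound 3 end at the limit, so the expected step is a step that the limit leaves unreadable from compound 3 to compound 4, nothing beyond the scatter. Compound 4 is expected to give 3000 nM in this assay, within 500 nM to 15000 nM, most likely reported again as a limit.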

Compound 4, solubility: < 5000 nM
Compound 4 was reported as a limit; the forecaster's own chance of this, stated with the estimate: 70%; the middle value is on the limit's open side.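

In this assay compound 4 is again reported only as a limit, < 5000 nM. With 4-carboxypyridin-2-yl on the nitrogen, the series shows an at least 23-fold lower number from compound 1 to compound 4 (1.36 log units; beyond the scatter) and an at least 40-fold lower number from compound 2 to compound 4 (1.60 log units; beyond the scatter), so a second carboxypyridinyl group now sits far under both compounds without a carboxylic acid. The step between compound 3 and compound 4 cannot be read, and both compounds sit at one limit: the limit of < 5000 nM in this assay, at which 2 of the 4 values shown sit.

On these data alone, whether the two carboxypyridinyl groups differ under that limit stays open. As far as these compounds go, what a methyl ester or a primary amide in place of the carboxylic acid would give also remains open.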